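The source may report more compounds than this note shows. Statements on the series, on what has been measured and on what is new or still open speak of the compounds shown alone.

The series is read in a functional assay on MCF7 cells (Homo sapiens) for cytotoxicity, read by sulforhodamine B assay, with a stated time of 3 days; on this read-out lower numbers stand for stronger inhibition and higher numbers for weaker inhibition. Compound 1 `O=[N+]([O-])c1ccccc1S(=O)(=O)N1CC(n2cnc3c(I)nc(Cl)nc32)OCc2ccccc21` gives 610 nM in this assay, the lowest of the two numbers recorded so far. Compound 2 `Cc1cn(C2CS(=O)(=O)c3ccccc3CO2)c(=O)[nH]c1=O` gives 12700 nM in this assay; the gap between the two lies beyond the scatter, but the two structures differ in more than one place, so the gap is a comparison of two numbers and not a single step. Compound 3 `O=[N+]([O-])c1ccccc1S(=O)(=O)N1CC(n2cnc3c(Br)ncnc32)OCc2ccccc21` has not yet been measured in this assay. It differs from compound 1 in one place: a group of 10 heavy atoms (5 carbon, 4 nitrogen, 1 bromine; one five-membered aromatic ring with 2 hetero atoms, one six-membered aromatic ring with 2 hetero atoms) in place of a group of 11 heavy atoms (5 carbon, 4 nitrogen, 1 chlorine, 1 iodine; one five-membered aromatic ring with 2 hetero atoms, one six-membered aromatic ring with 2 hetero atoms), on a saturated ring carbon. Among the compounds with values here, no step between measured compounds that differ in one place is known, so the numbers give no size for a change of this kind, and the expectation rests on the value of compound 1 alone. The expected step is a 1.8-fold higher number from compound 1 to compound 3 (0.26 log units; within the scatter), a mild weakening as the more likely direction, with a result inside the scatter also plausible. Compound 3 is accordingly estimated at 1100 nM in this assay, with a range from 300 nM to 4000 nM.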

Compound 3, half-maximal inhibitory concentration: 3620 nM
Beside the measured number, compound 3's estimate is 3.3-fold (0.52 log units) below it, within the range that was stated.
By their numbers in this assay, from the lowest: compound 1; then compound 3; then compound 2.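

Within the data shown here, this is the first one-place step. In this assay, the group of 10 heavy atoms with 1 bromine in place of the group of 11 heavy atoms with 1 chlorine and 1 iodine, on the saturated ring carbon next to the ring oxygen, gives a 5.9-fold higher number from compound 1 to compound 3 (0.77 log units; beyond the scatter), a modest weakening. The number at this position therefore responds to a change confined to the halogens of the group, since the two groups match in their aromatic rings, hydrogen-bond donors, hydrogen-bond acceptors and net charge, although nothing available accounts for the size or direction of this step.

The single step changes both halogens together, so the compounds shown cannot separate the loss of chlorine from the exchange of iodine for bromine. Still open, going by these compounds, is how the number would move with one halogen changed at a time, for example with chlorine retained alongside bromine, or with an amine or a methoxy group on the same aromatic rings.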